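Replacing a Chlorophenyl with a Trimethoxyphenyl: Expected Outcome

The compounds below may be only part of what the source reports. "The series", "measured", "known", "first", "only" and "open" are said of these compounds alone.

Compound 1 `CCC(C)C(N)c1cc(C(F)(F)F)ccc1N1CCN(C(=O)CCc2ccc(Cl)cc2Cl)CC1`: 160 nM
Compound 2 `CCC(C)[C@H](N)c1cc(C(F)(F)F)ccc1N1CCN(C(=O)CCc2ccc(OC)c(OC)c2Cl)CC1`: 2500 nM
Compound 3 `CC(C)C[C@H](N)c1cc(C(F)(F)F)ccc1N1CCN(C(=O)CCc2ccccc2Cl)CC1`: 1700 nM

All three share one core and were tested in an assay on HEK293 cells for displacement of a labelled ligand from Melanocortin receptor 4 (Homo sapiens); a higher number here means a weaker inhibitor, a lower number a stronger inhibitor. Compound 3 gives 1700 nM, the second highest of the three numbers; compound 2 lies within the scatter of it, whereas compound 1 gives 160 nM, a lower number beyond the scatter.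

Compound 4 `COc1cc(OC)c(OC)cc1CCC(=O)N1CCN(c2ccc(C(F)(F)F)cc2[C@@H](N)CC(C)C)CC1` is not yet measured. Within the data shown here, its only change from compound 3 is 2,4,5-trimethoxyphenyl in place of 2-chlorophenyl on a saturated chain carbon, two bonds along the chain from a carbonyl carbon. Among the measured compounds shown here, no measured pair shows this exact change, so its effect is uncertain. Compound 2, whose ring also carries methoxy groups, gives 2500 nM, within the scatter of compound 3. A small step toward a higher number, possibly none beyond the scatter, is therefore expected. Compound 4 is estimated at 3000 nM, with a range from 1000 nM to 9000 nM, which means an expected step of a 1.8-fold higher number from compound 3 to compound 4 (0.25 log units; within the scatter) in this assay.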

Compound 4, inhibition constant: 6100 nM
Compound 4: middle estimate off by 2.0-fold (0.31 log units), on the low side, within the range that was stated.
By their numbers in this assay, from the lowest: compound 1; then compounds 3 and 2 (each within the scatter of the next); then compound 4.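

In this assay, among these compounds, putting 2,4,5-trimethoxyphenyl in place of 2-chlorophenyl on this saturated chain carbon gives a 3.6-fold higher number from compound 3 to compound 4 (0.55 log units; beyond the scatter), the first single change in this set that can be read. It shows that the ring at this position does affect the number, with the trimethoxyphenyl compound being the weaker inhibitor of this pair. No measurement is available that would explain this step.

Which of the three methoxy groups matters remains open, since all of them enter together. So does whether a plain phenyl ring or a 2-methoxyphenyl ring here would give a lower or higher number.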